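The source may hold more compounds than are shown below. What is called first, only, known or untested is meant among the compounds shown, and "the series" means these compounds.

Measured in a functional assay on MDA-MB-231 cells (Homo sapiens) for antiproliferative activity, read by MTT assay, with a stated time of 72 h; on this read-out lower numbers stand for stronger inhibition and higher numbers for weaker inhibition:
- compound 1 `C#Cc1cccc(NC(=O)CCc2cccc3c2B(O)OC3)c1`: 1600 nM
- compound 2 `O=C(CCc1cccc2c1B(O)OC2)Nc1cccc(-c2ccc(F)cc2)c1`: 250 nM
- compound 3 `O=C(CCc1cccc2c1B(O)OC2)Nc1cccc(-c2cccc(Cl)c2)c1`: 250 nM

In this assay compound 3 gives 250 nM, level with compound 2 at 250 nM. Together they hold the lowest of the three numbers, and compound 1 stands higher at 1600 nM.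

Next is compound 4 `CSc1ccc(-c2cccc(NC(=O)CCc3cccc4c3B(O)OC4)c2)cc1`, with 4-(methylsulfanyl)phenyl in place of 3-chlorophenyl on an aromatic carbon, meta to a large group: 4-(methylsulfanyl)phenyl in place of 3-chlorophenyl on an aromatic carbon.

Two measured steps replace ethynyl with a substituted phenyl: a 6.4-fold lower number from compound 1 to compound 2 (0.81 log units; beyond the scatter) and a 6.4-fold lower number from compound 1 to compound 3 (0.81 log units; beyond the scatter). Both are modest and beyond the scatter, but neither exchanges one phenyl group for another. Among the measured compounds shown here, the closest precedent is no change at the digits printed from compound 2 to compound 3 (within the scatter), which stays within the scatter. For the measured compounds named here, no measured compound carries a methylsulfanyl group, so this precedent is limited.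

No step beyond the scatter is therefore expected in this assay. The estimated step is a 1.2-fold higher number from compound 3 to compound 4 (0.08 log units; within the scatter). Compound 4 is expected at 300 nM, with an estimated range of 110 nM to 800 nM.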

Compound 4, half-maximal inhibitory concentration: 140 nM
Beside the measured number, compound 4's estimate is 2.1-fold (0.33 log units) above it, and the stated range covers the measured number.
By their numbers in this assay, from the lowest: compounds 4, 2 and 3 (each within the scatter of the next); then compound 1.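

In this assay, 4-(methylsulfanyl)phenyl stays within the scatter of both earlier aryl groups (a 1.8-fold lower number from compound 3 to compound 4 (0.25 log units; within the scatter) and a 1.8-fold lower number from compound 2 to compound 4 (0.25 log units; within the scatter)), so this aromatic carbon now carries three differently substituted phenyl groups with no separable difference among them. Sulfur-bearing, fluoro and chloro substituents all fall in this one group, and the methylsulfanyl in place of fluoro comparison adds no measurable shift. Against ethynyl, the new group gives a large step (an 11-fold lower number from compound 1 to compound 4 (1.06 log units; beyond the scatter)), so all three phenyl compounds now stand apart from compound 1 beyond the scatter. No measurement here accounts for these results.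

Still open, going by these compounds, is whether a carboxylic acid or an amine on the phenyl ring would stay level with these aryl groups. A saturated ring such as piperidine in place of the phenyl ring is equally untested by the compounds shown.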